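The source may hold more compounds than are shown below. What is called first, only, known or untested is meant among the compounds shown, and "the series" means these compounds.

Compound 2 `O=c1cc(CNCc2cccc(F)c2)oc2ccc(O)c(O)c12` stands in an ADME assay on Huh-7 cells (Homo sapiens) for cytotoxicity (a lower number here means that less compound is tolerated, a higher number that more compound is tolerated), at a limit of the assay, > 100000 nM. Compound 1 `O=c1cc(CNCc2ccccc2Cl)oc2ccc(O)c(O)c12` also gives only a limit, > 100000 nM. Compound 3 `O=c1cc(CNCc2cccc(O)c2)oc2ccc(O)c(O)c12` likewise gives only a limit, > 100000 nM. On the numbers shown, compound 2 is therefore not separated from either neighbour. Compound 4 `Cc1ccc(CNCc2cc(=O)c3c(O)c(O)ccc3o2)cc1` differs from compound 2 by 4-methylphenyl in place of 3-fluorophenyl on a saturated chain carbon bound to an amine nitrogen. The measured steps that bear on this change, a step that the two limits leave unreadable from compound 1 to compound 2 and a step that the two limits leave unreadable from compound 2 to compound 3, are both unreadable because of the limit of > 100000 nM in this assay, at which 3 of the 3 values shown sit, at which every value shown sits. No size and no direction can thus be read for the expected step of a number no higher from compound 2 to compound 4 (the limit leaves the size open). Compound 4 is accordingly expected to give 100000 nM, within 50000 nM to 200000 nM, most probably reported again as a limit.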

Compound 4, half-maximal cytotoxic concentration: > 100000 nM
Compound 4: only a limit was reported; the forecaster's own chance of this, stated with the estimate: 85%; the middle value sits exactly at the limit.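

No step among compound 1, compound 2, compound 3 and compound 4 can be read, because each gives only a limit: the limit of > 100000 nM in this assay, at which 4 of the 4 values shown sit.

The compounds shown leave open whether changing the substituted phenyl group shifts the read-out in this assay at all.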